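The source may hold more compounds than are shown below. What is called first, only, known or untested is meant among the compounds shown, and "the series" means these compounds.

Measured so far: compound 1 `CCn1c(C(=O)NCCN)ccc1C(CC)(CC)c1ccc(OCCC(O)(CC)CC)c(C)c1` with 156 nM in an assay on cells for agonist activity at vitamin D3 receptor (Homo sapiens), with a stated time of 96 h; a lower number here means that less compound is needed, a higher number that more compound is needed for the effect; compound 2 `CCOc1ccc(NC(=O)c2ccc(C(CC)(CC)c3ccc(OCCC(O)(CC)CC)c(C)c3)n2CC)cc1` with 1630 nM.

For the measured compounds named here, compound 2 gives the highest of the two numbers in this assay, and the single measured step, a 10-fold higher number from compound 1 to compound 2 (1.02 log units; beyond the scatter), is large. Compound 3 `CCn1c(C(=O)N(C)CC(=O)O)ccc1C(CC)(CC)c1ccc(OCCC(O)(CC)CC)c(C)c1` carries the change ((carboxymethyl)(methyl)amino in place of (4-ethoxyphenyl)amino on a carbonyl carbon). That one step bears on it: placing 4-ethoxyphenyl in place of 2-aminoethyl on an amide-type nitrogen raised the number, and compound 3 again has a short substituent on that nitrogen, so a step back toward compound 1 is expected. Compound 3 is estimated at 350 nM, within 90 nM to 1400 nM, an expected 4.7-fold lower number from compound 2 to compound 3 (0.67 log units; beyond the scatter).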

Compound 3, half-maximal effective concentration: 89 nM
For compound 3 the middle estimate is 3.9-fold (0.59 log units) above the measured one, and the stated range ends above it.
By their numbers in this assay, from the lowest: compounds 3 and 1 (each within the scatter of the next); then compound 2.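

The step from an aromatic to a short open-chain substituent on this carbonyl carbon, with (carboxymethyl)(methyl)amino entering, gives an 18-fold lower number from compound 2 to compound 3 (1.26 log units; beyond the scatter) in this assay and so shows that the number can come back down without the (2-aminoethyl)amino group. The other step is a 1.8-fold lower number from compound 1 to compound 3 (0.24 log units; within the scatter) and leaves the substituents ending in an amine and in a carboxylic acid indistinguishable here. Nothing available explains these steps. From the compounds shown here alone, it remains open whether a methyl ester or a primary amide would match the carboxylic acid, and how a longer chain would read.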